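Swapping a para methyl for fluoro on a sulfonamide ring

The compounds below may be only part of what the source reports. "The series", "measured", "known", "first", "only" and "open" are said of these compounds alone.

Of the compounds shown here, three sharing one core have been measured in a functional assay (trachea) for antagonist activity, with Cavia porcellus as the target; a higher number here means a more potent compound, by a factor of ten per unit of this negative logarithm, a lower number a less potent compound. Compound 1 `CCCCC(CC)C(=O)Nc1ccc2ccn(Cc3ccc(C(=O)NS(=O)(=O)c4ccccc4)cc3OC)c2c1` gives 8.6. Compound 2 `CCCCC(CC)C(=O)Nc1ccc2ccn(Cc3ccc(C(=O)NS(=O)(=O)c4ccc([N+](=O)[O-])cc4)cc3OC)c2c1`, which carries a nitro group, gives 7.7. Compound 3 `CCCCC(CC)C(=O)Nc1ccc2ccn(Cc3ccc(C(=O)NS(=O)(=O)c4ccc(C)cc4)cc3OC)c2c1`, which carries a methyl group, gives 8.4; it stands second highest of the three, within the scatter of compound 1 and clearly above compound 2.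

The step to compound 4 `CCCCC(CC)C(=O)Nc1ccc2ccn(Cc3ccc(C(=O)NS(=O)(=O)c4ccc(F)cc4)cc3OC)c2c1` is fluoro in place of methyl on an aromatic carbon. Among the compounds with values here, no measured pair covers this exact swap. Within the data shown here, the steps that bear on it concern the same aromatic carbon: a number 0.20 log units lower from compound 1 to compound 3 (within the scatter), so adding methyl changed little; a number 0.90 log units lower from compound 1 to compound 2 (beyond the scatter) and a number 0.70 log units higher from compound 2 to compound 3 (beyond the scatter), so nitro at that carbon cost something. Fluoro here is a small, uncharged substituent, and the nearest precedent, methyl, sat within the scatter of hydrogen. The expectation is therefore a step of a number 0.10 log units lower from compound 3 to compound 4 (within the scatter), that is, no change beyond the scatter. Compound 4 is estimated at 8.3, ranging from 7.8 to 8.8 in this assay.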

Compound 4, negative logarithm of the antagonist equilibrium constant: 7.7
For compound 4 the middle estimate is 0.60 log units above the measured one; the whole stated range lies above it.
By their numbers in this assay, from the lowest: compounds 2 and 4 (each within the scatter of the next); then compounds 3 and 1 (each within the scatter of the next).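

In this assay, fluoro at this aromatic carbon is not a neutral replacement: in place of methyl it gives a number 0.70 log units lower from compound 3 to compound 4 (beyond the scatter), and in place of hydrogen it gives a number 0.90 log units lower from compound 1 to compound 4 (beyond the scatter). In place of nitro it gives no change at the digits printed from compound 2 to compound 4 (within the scatter), so the four compounds form two sets, hydrogen with methyl and fluoro with nitro, even though methyl and fluoro each count as one heavy atom. No measurement available here explains this grouping.

Going by these compounds, whether a chloro, methoxy or amino group at this carbon would sit with hydrogen and methyl or with fluoro and nitro remains open. The compounds shown vary only this one carbon, so they also leave open whether fluoro would have the same effect at another carbon of the ring.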